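Methyl in Place of Fluoro on the Aryl Urea

The source may report more compounds than this note shows. Statements on the series, on what has been measured and on what is new or still open speak of the compounds shown alone.

Compound 1, `O=C(Nc1cccc(C(=O)O)c1)N[C@H]1CC[C@H](Oc2ccc(F)cc2)CC1`, gives in a functional assay on CRL2813 cells (Homo sapiens) for cytotoxicity, read by sulforhodamine B assay, with a stated time of 5 days (on this read-out lower numbers stand for stronger inhibition and higher numbers for weaker inhibition), a limit of > 20000 nM.
Compound 2, `O=C(Nc1cccc(Cl)c1)N[C@H]1CC[C@H](Oc2ccc(F)cc2)CC1`, gives in this assay 5900 nM.
Compound 3, `O=C(Nc1ccccc1F)N[C@H]1CC[C@H](Oc2ccc(F)cc2)CC1`, gives in this assay 17500 nM.

Of the two numbers shown, compound 3 holds the higher one; the step of a 3.0-fold higher number from compound 2 to compound 3 (0.47 log units; beyond the scatter) separates it from compound 2. Compound 1 reports only a limit, (the limit of > 20000 nM in this assay, at which 1 of the 3 values shown sits), so its standing against compound 3 cannot be fixed beyond the step of an at least 1.1-fold lower number from compound 1 to compound 3 (0.05 log units; that floor lies within the scatter).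

Compound 4, `Cc1ccccc1NC(=O)N[C@H]1CC[C@H](Oc2ccc(F)cc2)CC1`, differs from compound 3 by methyl in place of fluoro on an aromatic carbon. Among the measured compounds shown here, none of the measured steps exchanges methyl for fluoro. The steps of an at least 3.3-fold lower number from compound 1 to compound 2 (0.53 log units; beyond the scatter) and a 3.0-fold higher number from compound 2 to compound 3 (0.47 log units; beyond the scatter) swap the whole aryl substituent, and both fall in the modest range; the closest comparison, compound 2 against compound 3, shows that a single small aromatic group can move the number modestly. For compound 4 a step of a 1.5-fold lower number from compound 3 to compound 4 (0.16 log units; within the scatter) is therefore expected, at most modest and possibly within the scatter. Compound 4 is estimated at 12000 nM, within 4000 nM to 35000 nM.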

Compound 4, half-maximal inhibitory concentration: > 20000 nM
Compound 4: no number, only a limit; the forecaster's own chance of this, stated with the estimate: 25%; middle value at least 1.6-fold (0.22 log units) from the limit.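

Compound 4 gives only a limit in this assay, so the step of an at least 1.1-fold higher number from compound 3 to compound 4 (0.05 log units; that floor lies within the scatter) shows that methyl in place of fluoro, on an aromatic carbon ortho to a large group, brings no readable gain at this position. Measured against the 3-chlorophenyl urea, the 2-methylphenyl urea gives an at least 3.3-fold higher number from compound 2 to compound 4 (0.53 log units; beyond the scatter), so compound 4, like compound 3, stands on the weak side of compound 2. The step between compound 1 and compound 4 cannot be read, as both values are limits: the limit of > 20000 nM in this assay, at which 2 of the 4 values shown sit.

As far as these compounds go, how far methyl and fluoro truly differ here stays open, since compound 4 has no number. Also open, from the compounds shown here alone, is whether chloro, methoxy or an amine at this same position would give a number lower than those of compound 3 and compound 4.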